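Phenyl for methyl on the shared core: expected lipophilicity

The source may report more compounds than this note shows. Statements on the series, on what has been measured and on what is new or still open speak of the compounds shown alone.

Measured so far:
compound 1, `O=c1c2ccccc2nc(-c2ccccc2)n1/N=C/c1ccc(Oc2ccccc2)cc1`, 6.13
compound 2, `Cc1cc(Oc2ccc(/C=N/n3c(C)nc4ccccc4c3=O)cc2)ccc1Cl`, 4.41

Among the measured compounds shown here, the two measured compounds share a core and differ in more than one place, so no single step between them is worked out. In a physicochemical assay for lipophilicity, in phosphate buffer, measured as octanol-water partition (a lower number here means a more polar compound, a higher number a more lipophilic compound), compound 2 gives 4.41, the lower of the two numbers. Where compound 2 carries a methyl on the core, a phenyl sits in compound 1, and in this assay compound 1 gives 6.13, a gap that lies well beyond the scatter.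

Compound 3, `Cc1cc(Oc2ccc(/C=N/n3c(-c4ccccc4)nc4ccccc4c3=O)cc2)ccc1Cl`, has not yet been measured. It keeps everything of compound 2 except one change: phenyl in place of methyl on an aromatic carbon. For the measured compounds named here, the only comparison at hand is compound 1, whose value of 6.13 in this assay comes with a phenyl at that same place. On that basis the change from compound 2 to compound 3 is expected to raise the partition coefficient clearly, by an amount estimated as a number 1.79 log units higher from compound 2 to compound 3 (beyond the scatter). For compound 3 the value in this assay is therefore estimated at 6.2, with a likely range from 5.3 to 7.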

Compound 3, partition coefficient: 6.52
Estimate against measurement, compound 3: 0.32 log units below; measured number inside the range.
By their numbers in this assay, from the lowest: compound 2; then compound 1; then compound 3.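

In this assay, phenyl in place of methyl on an aromatic carbon, between two ring nitrogen atoms, can now be read on its own, with the rest of the molecule unchanged, and the step is large (a number 2.11 log units higher from compound 2 to compound 3 (beyond the scatter)). The other end of the molecule can also be read on its own: with phenyl on the core in both compounds, 4-chloro-3-methylphenyl in place of phenyl on an oxygen on an aromatic ring gives a modest step (a number 0.39 log units higher from compound 1 to compound 3 (beyond the scatter)). Each change moves the number beyond the scatter, and of the two, the change on the core gives the larger step, so this position on the core matters more here than the change at the far end of the molecule.

Nothing shown gives a reason for either step. Still open, as far as these compounds go, is how an amine or a carboxylic acid at this place on the core would read in this assay, and whether phenyl in place of methyl would give a step of similar size with an unsubstituted phenyl on the oxygen.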